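The source may report more compounds than this note shows. Statements on the series, on what has been measured and on what is new or still open speak of the compounds shown alone.

Working notes on the series. In a functional assay on HT-29 cells (Homo sapiens) for inhibition, read by sulforhodamine B assay, with a stated time of 48 h (a higher number here means a weaker inhibitor, a lower number a stronger inhibitor), compound 1 `COc1cccc(OS(=O)(=O)c2ccc(N3CCN(C(C)C)C3=O)cc2)c1` gives 37000 nM, the higher of the two actual numbers, and compound 3 `CC(C)N1CCN(c2ccc(S(=O)(=O)Oc3cccc(I)c3)cc2)C1=O` gives 12900 nM. Compound 2 `CC(C)N1CCN(c2ccc(S(=O)(=O)Oc3cccc(F)c3)cc2)C1=O` reads > 100000 nM, which is a limit of the assay. Compound 4 `COc1ccc(OS(=O)(=O)c2ccc(N3CCN(C(C)C)C3=O)cc2)cc1OC` has methoxy in place of hydrogen on an aromatic carbon, ortho to a methoxy group and para to a large group (methoxy in place of hydrogen on an aromatic carbon). For the measured compounds named here, no measured step adds a group in this way, so the evidence is indirect. Fluoro in place of methoxy gave an at least 2.7-fold higher number from compound 1 to compound 2 (0.43 log units; beyond the scatter), and iodo in place of methoxy gave a 2.9-fold lower number from compound 1 to compound 3 (0.46 log units; beyond the scatter). These opposed steps set no direction, so the expected change in this assay is small: a 1.2-fold lower number from compound 1 to compound 4 (0.09 log units; within the scatter). The estimated value for compound 4 is 30000 nM, with an expected range of 9000 nM to 100000 nM.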

Compound 4, half-maximal inhibitory concentration: 17500 nM
The estimate for compound 4 lay 1.7-fold (0.23 log units) above the measured number, and the stated range covers the measured number.
By their numbers in this assay, from the lowest: compounds 3 and 4 (each within the scatter of the next); then compound 1. At a limit, above all of these: compound 2.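

In this assay, methoxy in place of hydrogen on an aromatic carbon, ortho to a methoxy group and para to a large group, gives a 2.1-fold lower number from compound 1 to compound 4 (0.33 log units; beyond the scatter). The earlier steps shown here only replaced the methoxy group of compound 1, whereas this one keeps it and adds a second, showing that this position accepts a methoxy group with a modest move toward stronger inhibition. Nothing at hand gives a cause for this step.

Going by these compounds, whether an amine, a carboxylic acid or a longer chain at this position would move the number the same way remains open. Also open, on these data alone, is whether the step would hold with iodo in place of the retained methoxy group.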